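The compounds below may be only part of what the source reports. "The series", "measured", "known", "first", "only" and "open" are said of these compounds alone.

Measured compounds:
compound 1, `CCC(=O)Nc1ccc(-c2nc3cc(C(F)(F)F)ccc3n2C2CCCCC2)cc1`, 18000 nM
compound 2, `CCC(=O)Nc1ccc(-c2nc3cc(C(F)(F)F)ccc3[nH]2)cc1`, > 100000 nM
compound 3, `Fc1ccc(-c2nc3cc(C(F)(F)F)ccc3[nH]2)cc1`, 19000 nM

In an ADME assay on MDBK cells (Bos taurus) for cytotoxicity, read by MTT assay, with a stated time of 96 h (on this read-out higher numbers stand for lower toxicity in this test and lower numbers for higher toxicity in this test), compound 1 gives 18000 nM. Compound 3 gives 19000 nM in this assay, a number that sits within the scatter of the value of compound 1. Compound 2 reaches only the limit of the assay, > 100000 nM, so for it no number is known (the limit of > 100000 nM in this assay, at which 1 of the 3 values shown sits).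

Two steps among these compounds lie beyond the scatter. The step of an at least 5.5-fold higher number from compound 1 to compound 2 (0.74 log units; beyond the scatter) comes with hydrogen in place of cyclohexyl on an aromatic nitrogen. The step of an at least 5.2-fold lower number from compound 2 to compound 3 (0.72 log units; beyond the scatter) comes with fluoro in place of propanoylamino on an aromatic carbon.

The unmeasured compound is compound 4, `Nc1ccc(-c2nc3cc(C(F)(F)F)ccc3n2C2CCCCC2)cc1`. It differs from compound 1 by hydrogen in place of propanoyl on a nitrogen on an aromatic ring. Neither measured step matches this change: the step from compound 1 to compound 2 alters the nitrogen of the shared core, and the step from compound 2 to compound 3 removes the whole propanoylamino group on a core that carries hydrogen on its aromatic nitrogen. Only a modest shift, if any, is therefore expected, and its direction is uncertain; the step of a 1.5-fold lower number from compound 1 to compound 4 (0.18 log units; within the scatter) is an estimate of that kind. Compound 4 is expected to give about 12000 nM in this assay, within a range from 3000 nM to 50000 nM.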

Compound 4, half-maximal cytotoxic concentration: > 100000 nM
Compound 4: only a limit was reported; the forecaster's own chance of this, stated with the estimate: 10%; at least 8.3-fold (0.92 log units) between middle value and limit.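

Taking only the propanoyl off the nitrogen on the aromatic ring, so that propanoylamino becomes amino, gives an at least 5.5-fold higher number from compound 1 to compound 4 (0.74 log units; beyond the scatter) in this assay, which means lower toxicity in this test. Within the data shown here, the earlier compounds could not show this, since the only change at this place swapped the whole propanoylamino group for fluoro, and it did so on a core that carries hydrogen on its aromatic nitrogen. The result also shows that, with the cyclohexyl group kept, this nitrogen is a place where a small change moves the read-out, and that the move has the same direction as an at least 5.5-fold higher number from compound 1 to compound 2 (0.74 log units; beyond the scatter), so either removal from compound 1 raises the number.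

On these data alone, how far the step really reaches stays open, because compound 4 sits at a limit and not at a number: the limit of > 100000 nM in this assay, at which 2 of the 4 values shown sit. The compounds shown also leave open whether a shorter acetyl group, a longer acyl chain or a simple methyl on this nitrogen would read like propanoyl or like hydrogen, and so whether the chain length or the carbonyl goes with the change.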